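Compound 2 and Its Selenium Counterpart, Compound 4

The source may report more compounds than this note shows. Statements on the series, on what has been measured and on what is new or still open speak of the compounds shown alone.

In an ADME assay on cells (Fibroblast, Homo sapiens) for cytotoxicity, read by MTT assay, with a stated time of 24 h (a lower number here means a stronger inhibitor, a higher number a weaker inhibitor), compound 2 (`COc1ccc(N(CC(=O)NCCC[Te]c2ccccc2)C(=O)CNC(=O)OC(C)(C)C)cc1`) gives 25000 nM. Compound 1 (`COc1ccc(N(CC(=O)NCCCSc2ccccc2)C(=O)CCSC2=C(C)C(=O)c3ccccc3C2=O)cc1`) gives 26000 nM, which is within the usual scatter of compound 2. Compound 3 (`O=C(COC(=O)/C=C/c1ccccc1)NCCC[Te]c1ccccc1`) gives 11000 nM, a clearly lower number than compound 2, so compound 2 stands level with compound 1 and apart from compound 3.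

Compound 4 (`COc1ccc(N(CC(=O)NCCC[Se]c2ccccc2)C(=O)CNC(=O)OC(C)(C)C)cc1`) is compound 2 with a single change: a group of 7 heavy atoms (6 carbon, 1 selenium; one six-membered aromatic ring of carbon only) in place of a group of 7 heavy atoms (6 carbon, 1 tellurium; one six-membered aromatic ring of carbon only), on a saturated chain carbon, three bonds along the chain from an amide-type nitrogen. The swap sits on a saturated chain carbon, three bonds along the chain from an amide-type nitrogen, and the rest of the molecule stays the same.

For the measured compounds named here, no measured pair here shows this swap on its own, so any forecast is uncertain. Compound 1 holds sulfur where compound 2 holds tellurium and differs elsewhere too, yet compound 1 still gives 26000 nM. A step no larger than the scatter is therefore expected, and the estimated change is a 1.2-fold higher number from compound 2 to compound 4 (0.08 log units; within the scatter). For compound 4 the estimated value is 30000 nM, with an expected range from 13000 nM to 70000 nM.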

Compound 4, half-maximal inhibitory concentration: >= 100000 nM
Compound 4 was reported as a limit; the forecaster's own chance of this, stated with the estimate: 10%; at least 3.3-fold (0.52 log units) between middle value and limit.
By their numbers in this assay, from the lowest: compound 3; then compounds 2 and 1 (each within the scatter of the next). At a limit, above all of these: compound 4.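

Within the shared core, a group of 7 heavy atoms carrying selenium in place of one carrying tellurium gives an at least 4.0-fold higher number from compound 2 to compound 4 (0.60 log units; beyond the scatter), on a saturated chain carbon, three bonds along the chain from an amide-type nitrogen. For the compounds shown here, the earlier compounds offered no pair isolating this swap, and this pair shows that the single atom change alone can move the number in this assay beyond the scatter. Compound 4 is reported only as a limit, >= 100000 nM, and the full size of the step cannot be read because of this: the limit of >= 100000 nM in this assay, at which 1 of the 4 values shown sits.

As far as these compounds go, it remains open whether the same swap would give a similar step on compound 3, which also carries tellurium. From the compounds shown here alone, it is also open how an oxygen atom or a sulfur atom in that spot on compound 2, or a longer chain, would read in this assay.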